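The source may hold more compounds than are shown below. What is called first, only, known or untested is meant among the compounds shown, and "the series" means these compounds.

Compound 1 `CCCC(CCC)C(=O)OCC1(CO)C/C(=C/c2ccncc2)C(=O)O1`: 2.9
Compound 2 `CCCC(CCC)C(=O)OCC1(CO)C/C(=C\c2cccnc2)C(=O)O1`: 2.9

Both values come from a physicochemical assay for lipophilicity (on this read-out lower numbers stand for lower lipophilicity and higher numbers for higher lipophilicity), and compound 2 stands level with compound 1, within the usual scatter of repeated measurements. Still unmeasured is compound 3 `CCCC(CCC)C(=O)OCC1(CO)C/C(=C\c2ccncc2)C(=O)O1`. The structural change from compound 2 is confined to one place: pyridin-4-yl in place of pyridin-3-yl on a double-bonded chain carbon bound to a double-bonded ring carbon. Here pyridin-4-yl takes the place of pyridin-3-yl on a double-bonded chain carbon bound to a double-bonded ring carbon, so the same atoms are joined differently. Within the data shown here, no two measured compounds differ in just one place, so the data contain no direct measure of such a swap. The expectation therefore starts from compound 2 at 2.9. The expected step is no change at the digits printed from compound 2 to compound 3 (within the scatter), which means none beyond the scatter. For compound 3, the estimated value is 2.9, with an expected range of 2.6 to 3.2.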

Compound 3, partition coefficient: 2.9
Compound 3: middle estimate and measured number agree at the digits printed, within the range that was stated.
By their numbers in this assay, from the lowest: compounds 1, 2 and 3 (each within the scatter of the next).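

In this assay, among these compounds, pyridin-4-yl in place of pyridin-3-yl on a double-bonded chain carbon bound to a double-bonded ring carbon gives no change at the digits printed from compound 2 to compound 3 (within the scatter), the first direct reading of this swap. Compound 1 and compound 3 have the same atoms and bonds, and the double bond drawn Z in one and E in the other gives no change at the digits printed from compound 1 to compound 3 (within the scatter). This second comparison needs some care in reading, and one point limits it: the fact that one of compounds 1 and 3 is drawn with a defined configuration and the other without, at the place where they differ

Going by these compounds, all three compounds carry a pyridine ring on the same core, so the result of a pyridin-2-yl or a phenyl group at this place in this assay stays open. Also open, on these data alone, is whether an amine or a carboxylic acid on that ring would move the number beyond the scatter.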